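The compounds below may be only part of what the source reports. "The series", "measured", "known", "first", "only" and "open" are said of these compounds alone.

Compound 2 `COc1cc(-c2nn(-c3cccc(NC(=O)c4cccc(C(F)(F)F)c4)c3)cc2-c2ccncc2)ccc1Cl` gives 811 nM in a functional assay on RXF 393 cells (Homo sapiens) for inhibition, read by sulforhodamine B assay, with a stated time of 48 h (a lower number here means a stronger inhibitor of growth, a higher number a weaker inhibitor of growth), the lowest of the three numbers measured; compound 3 `O=C(Nc1cccc(-n2cc(-c3ccncc3)c(-c3ccc(Cl)c(O)c3)n2)c1)Nc1cc(C(F)(F)F)cc(C(F)(F)F)c1` gives 937 nM, which lies within the scatter of compound 2, while compound 1 `O=C(Nc1cccc(-n2cc(-c3ccncc3)c(-c3ccc(Cl)c(O)c3)n2)c1)Nc1cccc(C(F)(F)F)c1` gives 3020 nM, beyond it. Compound 4 `COc1cc(-c2nn(-c3cccc(NC(=O)Nc4ccc(Cl)c(C(F)(F)F)c4)c3)cc2-c2ccncc2)ccc1Cl` carries (4-chloro-3-(trifluoromethyl)phenyl)amino in place of 3-(trifluoromethyl)phenyl on a carbonyl carbon. Going by the values given here, the only single-step change measured, a 3.2-fold lower number from compound 1 to compound 3 (0.51 log units; beyond the scatter), concerns a trifluoromethyl on the urea aryl of compound 1, not the amide-to-urea exchange made here, so no measured step speaks directly to it; compounds 1 and 3 show only that ureas of this kind fall near compound 2. Compound 4 is therefore expected to change by a 1.4-fold lower number from compound 2 to compound 4 (0.13 log units; within the scatter), giving an estimated 600 nM, between 200 nM and 2000 nM.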

Compound 4, concentration for 50% growth inhibition: 1180 nM
Beside the measured number, compound 4's estimate is 2.0-fold (0.29 log units) below it; measured number inside the range.
By their numbers in this assay, from the lowest: compounds 2, 3 and 4 (each within the scatter of the next); then compound 1.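

In this assay, the step of a 1.5-fold higher number from compound 2 to compound 4 (0.16 log units; within the scatter) shows that this carbonyl carbon accepts (4-chloro-3-(trifluoromethyl)phenyl)amino in place of 3-(trifluoromethyl)phenyl with no change beyond the scatter. The earlier compounds shown here offered no direct comparison of these two groups at this position. The exchange adds an amino nitrogen and a chlorine together, so their separate contributions cannot be told apart, and no supporting measurement explains the result. Going by these compounds, it remains open how either addition would behave alone, and how a piperidine on the same carbonyl carbon would affect growth inhibition.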